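Trimming the Carbamate Tail: Permeability Outlook for Compound 4

The source may hold more compounds than are shown below. What is called first, only, known or untested is meant among the compounds shown, and "the series" means these compounds.

Compound 1 `Cn1cncc1CN1CC(N(CC2CCN(C(=O)CNC(=O)OC(C)(C)C)CC2)S(=O)(=O)c2ccccn2)Cc2cc(C#N)ccc21`: 0.5 10^-6 cm/s
Compound 2 `CC(C)S(=O)(=O)N1CCC(CN(C2Cc3cc(C#N)ccc3N(Cc3cncn3C)C2)S(=O)(=O)c2ccccn2)CC1`: 0.1 10^-6 cm/s
Compound 3 `Cn1cncc1CN1CC(N(CC2CCN(C(=O)N3CCCC3)CC2)S(=O)(=O)c2ccccn2)Cc2cc(C#N)ccc21`: 0.6 10^-6 cm/s

In an ADME assay on Caco-2 cells (Homo sapiens) for permeability, in the apical to basolateral direction (on this read-out higher numbers stand for higher permeability and lower numbers for lower permeability), compound 1 stands second highest of the three measured numbers. The step of a 1.2-fold higher number from compound 1 to compound 3 (0.08 log units; within the scatter) lies within the scatter, whereas the step of a 5.0-fold lower number from compound 1 to compound 2 (0.70 log units; beyond the scatter) is a modest drop. Compound 4 `C=C(C)C(=O)N1CCC(CN(C2Cc3cc(C#N)ccc3N(Cc3cncn3C)C2)S(=O)(=O)c2ccccn2)CC1` has not yet been measured; it differs from compound 1 in one place: 1-methylethenyl in place of ((tert-butoxycarbonyl)amino)methyl on a carbonyl carbon. Both measured steps change the same carbonyl-bearing position, one leaving the number unchanged and one lowering it. Compound 4 is therefore expected to stay close to compound 1, with an expected step of a 1.2-fold higher number from compound 1 to compound 4 (0.08 log units; within the scatter). For compound 4 the estimate in this assay is 0.6 10^-6 cm/s, expected to fall between 0.2 10^-6 cm/s and 1.5 10^-6 cm/s.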

Compound 4, apparent permeability: 0.5 10^-6 cm/s
Compound 4: middle estimate off by 1.2-fold (0.08 log units), on the high side; the range from low to high includes it.
By their numbers in this assay, from the lowest: compound 2; then compounds 1, 4 and 3 (each within the scatter of the next).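

In this assay, the ((tert-butoxycarbonyl)amino)methyl group on this carbonyl carbon can be replaced by the much smaller 1-methylethenyl, which has no hydrogen-bond donor or acceptor, with no real shift (no change at the digits printed from compound 1 to compound 4 (within the scatter)). The pyrrolidin-1-yl comparison is also within the scatter (a 1.2-fold lower number from compound 3 to compound 4 (0.08 log units; within the scatter)), so these three different groups give similar numbers. Replacing isopropylsulfonyl with (1-methylethenyl)carbonyl gives a step beyond the scatter (a 5.0-fold higher number from compound 2 to compound 4 (0.70 log units; beyond the scatter)), so the gap already seen with the other two carbonyl compounds holds here too.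

Nothing shown gives a reason for these numbers. From the compounds shown here alone, whether a free amine or a carboxylic acid on this carbonyl carbon would stay in the same range remains open.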